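A few compounds are considered here, and "the series" means these few. Any claim that something is new, unique, unknown or untested is made for them only; others in the source may bear on it.

Of the compounds shown here, three built on one shared core have been tested in a functional assay on NCI-H322M cells (Homo sapiens) for cytotoxicity, read by sulforhodamine B assay, with a stated time of 48 h; a higher number here means a weaker inhibitor of growth, a lower number a stronger inhibitor of growth. Compound 1, `Nc1nc(Cl)c2ncn(Cc3ccccc3CCl)c2n1`, gives 29500 nM in this assay. Compound 2, `ClCc1cccc(Cn2cnc3nc(Cl)nc(Cl)c32)c1`, gives 26900 nM in this assay. Compound 3, `ClCc1ccccc1Cn1cnc2nc(Cl)nc(Cl)c21`, gives 14500 nM in this assay. On these numbers compound 3 stands at a gap from compound 1 that is beyond the usual scatter of repeated measurements, while its gap from compound 2 lies within that scatter, so compound 3 and compound 2 cannot be told apart on this evidence. Among the measured compounds shown here, no two of the three compounds differ in only one place, so no single step has been measured.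

The next compound, compound 4, `ClCc1ccccc1Cn1cnc2ncnc(Cl)c21`, has not yet been measured. It differs from compound 3 in one place:

hydrogen in place of chloro on an aromatic carbon

A chloro group on the core is replaced by hydrogen. Without a measured step of this kind to lean on, the expectation is a modest weakening of growth inhibition, with the step in this assay from compound 3 to compound 4 estimated as a 1.5-fold higher number from compound 3 to compound 4 (0.18 log units; within the scatter), a change that may not rise beyond the scatter. For compound 4 in this assay the estimated value is 22000 nM, within a range from 9000 nM to 60000 nM.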

Compound 4, concentration for total growth inhibition: 15800 nM
Compound 4: the middle estimate sits 1.4-fold (0.14 log units) above what was measured, and the stated range covers the measured number.
By their numbers in this assay, from the lowest: compounds 3, 4, 2 and 1 (each within the scatter of the next, the first and the last beyond it).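

Compound 3 and compound 4 form the first single step measured in this set, and it concerns the chloro group on the aromatic carbon between two ring nitrogen atoms. In this assay, replacing that chloro group with hydrogen gives a 1.1-fold higher number from compound 3 to compound 4 (0.04 log units; within the scatter), so the two compounds cannot be told apart and growth inhibition in these cells does not measurably depend on this chloro group, at least with the rest of compound 3 held fixed. No measurement available here accounts for this result.

From the compounds shown here alone, what stays open is whether this carbon accepts larger or different groups just as readily, such as a methoxy group or a carboxylic acid, since hydrogen and chloro are the only two compared here in a single step. Going by these compounds, it is also open whether the chloro group that stays on the core in compound 4 can be replaced by hydrogen with as little effect, or whether the remaining growth inhibition depends on that group.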